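The source may hold more compounds than are shown below. What is called first, only, known or untested is meant among the compounds shown, and "the series" means these compounds.

Measured compounds:
compound 1, `Cc1cc(C)c(-c2nc3ccccc3[nH]2)cc1NC(=O)c1ccc(OCc2ccccn2)cc1`, 21 mL.min-1.g-1
compound 2, `Cc1cc(C)c(-c2c(C)nn(C)c2C)cc1NC(=O)c1ccc(OCc2ccccn2)cc1`, 271 mL.min-1.g-1

Among the compounds with values here, in an ADME assay on microsomes from liver (Rattus norvegicus) for metabolic stability (a lower number here means slower removal, a higher number faster removal of the compound), compound 2 stands at the highest of the two numbers so far; its only neighbour is compound 1, which in this assay gives 21 mL.min-1.g-1, and the step of a 13-fold higher number from compound 1 to compound 2 (1.11 log units; beyond the scatter) is large and well beyond the scatter.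

Compound 3, `Cc1cc(C)c(-c2ccccn2)cc1NC(=O)c1ccc(OCc2ccccn2)cc1`, has not yet been measured in this assay. It differs from compound 2 by pyridin-2-yl in place of 1,3,5-trimethyl-1H-pyrazol-4-yl on an aromatic carbon. Within the data shown here, the one measured step that bears on this position is the exchange from compound 1 to compound 2, which moved the number upward by a large margin. Among the measured compounds shown here, no measured pair joins a pyridin-2-yl to either of the groups seen so far, so the direction can only be read loosely from that single large step. On that basis compound 3 is expected to return part of the way toward compound 1, giving a step of a 3.0-fold lower number from compound 2 to compound 3 (0.48 log units; beyond the scatter) in this assay. The estimate for compound 3 in this assay is 90 mL.min-1.g-1, with a range from 25 mL.min-1.g-1 to 300 mL.min-1.g-1.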

Compound 3, intrinsic clearance in microsomes in the Rattus norvegicus assay: 296 mL.min-1.g-1
Estimate against measurement, compound 3: 3.3-fold (0.52 log units) below; the range from low to high includes it.
By their numbers in the Rattus norvegicus assay, from the lowest: compound 1; then compounds 2 and 3 (each within the scatter of the next).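

In the Rattus norvegicus assay, pyridin-2-yl and 1,3,5-trimethyl-1H-pyrazol-4-yl cannot be told apart at this position, a 1.1-fold higher number from compound 2 to compound 3 (0.04 log units; within the scatter), although a six-membered aromatic ring with one hetero atom replaces a five-membered one with two. Set against 1H-benzimidazol-2-yl in the Rattus norvegicus assay, pyridin-2-yl gives a 14-fold higher number from compound 1 to compound 3 (1.15 log units; beyond the scatter), so among these three compounds only compound 1, with its 1H-benzimidazol-2-yl group, stands apart from the others, and a single compound cannot show which feature of that group sets it apart. In a physicochemical assay for solubility, at pH 7.4 (on this read-out higher numbers stand for higher solubility and lower numbers for lower solubility), compound 2 gives 35000 nM. In the physicochemical assay compound 3 gives < 1000 nM, a limit of the assay and not a number: the limit of < 1000 nM in the physicochemical assay, at which 1 of the 2 values shown sits. The same exchange does separate the two compounds in the physicochemical assay, with an at least 35-fold lower number from compound 2 to compound 3 (1.54 log units; beyond the scatter).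

The compounds shown leave open whether a smaller ring such as 1H-imidazol-2-yl would sit with compound 1 or with compound 3 in the Rattus norvegicus assay. They also leave open whether an amine or a carboxylic acid on the pyridin-2-yl ring would change the picture in the Rattus norvegicus assay or in the physicochemical assay.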